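Swapping nitro for trifluoromethyl: compound 3 to compound 4

The source may hold more compounds than are shown below. What is called first, only, known or untested is meant among the compounds shown, and "the series" means these compounds.

The series shares one core and varies a single substituent on a six-membered aromatic ring of carbon only. Compound 1 `COc1ccc(C(=O)/C=C/c2ccc(Br)cc2)c2c1C=CC(C)(C)O2` carries bromo; in a functional assay on K562 cells (Homo sapiens) for antiproliferative activity, read by MTT assay, with a stated time of 24 h (a lower number here means a stronger inhibitor, a higher number a weaker inhibitor), compound 1 gives only a limit, > 10000 nM (the limit of > 10000 nM in this assay, at which 1 of the 3 values shown sits). Compound 2 `COc1ccc(C(=O)/C=C/c2ccc(N(C)C)cc2)c2c1C=CC(C)(C)O2` carries dimethylamino, and in this assay compound 2 gives 3500 nM. Compound 3 `COc1ccc(C(=O)/C=C/c2ccc([N+](=O)[O-])cc2)c2c1C=CC(C)(C)O2` carries nitro, and in this assay compound 3 gives 7770 nM, the higher of the two numbers shown; the step of a 2.2-fold higher number from compound 2 to compound 3 (0.35 log units; beyond the scatter) lies beyond the scatter, while an at least 1.2-fold lower number from compound 1 to compound 3 (0.10 log units; that floor lies within the scatter) has its floor within it.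

Compound 4 `COc1ccc(C(=O)/C=C/c2ccc(C(F)(F)F)cc2)c2c1C=CC(C)(C)O2` differs from compound 3 in one place: trifluoromethyl in place of nitro on an aromatic carbon. Within the data shown here, no measured step involves trifluoromethyl, so the only guide is the size of the substituent swaps seen so far, an at least 2.8-fold lower number from compound 1 to compound 2 (0.45 log units; beyond the scatter) and a 2.2-fold higher number from compound 2 to compound 3 (0.35 log units; beyond the scatter), both modest. A step of similar size in this assay is therefore the most to expect, in either direction, and a change within the scatter is at least as likely; a further limit cannot be ruled out. The estimate for compound 4 in this assay is 9000 nM, with a range from 4000 nM to 20000 nM. This corresponds to an expected step of a 1.2-fold higher number from compound 3 to compound 4 (0.06 log units; within the scatter).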

Compound 4, half-maximal inhibitory concentration: > 10000 nM
Compound 4: no number, only a limit; the forecaster's own chance of this, stated with the estimate: 35%; middle value at least 1.1-fold (0.04 log units) from the limit.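

In this assay compound 4 gives > 10000 nM, which is a limit of the assay and not a number. Dimethylamino now stands apart from a further substituent at this position, para to a large group, with an at least 2.8-fold higher number from compound 2 to compound 4 (0.45 log units; beyond the scatter), while the step from nitro, an at least 1.2-fold higher number from compound 3 to compound 4 (0.10 log units; that floor lies within the scatter), has its floor within the scatter, so trifluoromethyl and nitro are not separated in these data. Compound 2 is now the strongest of the four, with steps beyond the scatter to each of the other three, and a second compound has reached the limit: the limit of > 10000 nM in this assay, at which 2 of the 4 values shown sit.

As far as these compounds go, the step between compound 1 and compound 4 cannot be read, and how far either compound lies past the limit stays unknown. From the compounds shown here alone, whether the lower number of compound 2 belongs to dimethylamino alone, or also appears with a primary amine, a methoxy group or a hydroxyl group at this position, remains open.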